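A few compounds are considered here, and "the series" means these few. Any claim that something is new, unique, unknown or untested is made for them only; others in the source may bear on it.

In a functional assay on ECV-304 cells (Homo sapiens) for cytotoxicity (on this read-out lower numbers stand for stronger inhibition and higher numbers for weaker inhibition), compound 1 `Cc1ccc(/C=C2\SC(=S)N(NS(=O)(=O)c3ccccc3)C2=O)cc1` gives > 50000 nM, which is a limit and not a number. Compound 2 `O=C1/C(=C/c2ccccc2F)SC(=S)N1NS(=O)(=O)c1ccccc1` gives > 50000 nM, again a limit. Compound 3 `O=C1/C(=C/c2ccc(F)cc2F)SC(=S)N1NS(=O)(=O)c1ccccc1` gives > 50000 nM, also a limit, so it stands with the other two and has no number of its own. Within the data shown here, the whole series so far is summed up as the limit of > 50000 nM in this assay, at which 3 of the 3 values shown sit.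

Compound 4 `O=C1/C(=C/c2cc(F)ccc2F)SC(=S)N1NS(=O)(=O)c1ccccc1` keeps the shared core and moves one fluorine: 2,5-difluorophenyl in place of 2,4-difluorophenyl on a double-bonded chain carbon bound to a double-bonded ring carbon. This is 2,5-difluorophenyl in place of 2,4-difluorophenyl on a double-bonded chain carbon bound to a double-bonded ring carbon.

The closest measured change is the added fluoro on an aromatic carbon, which is a step that the two limits leave unreadable from compound 2 to compound 3. The exchanges of 4-methylphenyl are no more informative, being a step that the two limits leave unreadable from compound 1 to compound 2 and a step that the two limits leave unreadable from compound 1 to compound 3. Among the measured compounds shown here, none of these steps has a readable size, but every fluorinated compound measured so far, compound 2 and compound 3, stays at the limit, and compound 1 does the same without fluorine.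

No shift in either direction is therefore expected in this assay beyond the scatter. The expected outcome is a number no higher from compound 3 to compound 4 (the limit leaves the size open). For compound 4 the estimated value is 50000 nM, with an expected range of 25000 nM to 100000 nM, and most likely the assay will again report only a limit.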

Compound 4, half-maximal inhibitory concentration: > 50000 nM
Compound 4: only a limit was reported (the forecaster's own chance of this, stated with the estimate: 85%); the middle value sits exactly at the limit.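

In this assay compound 4 gives > 50000 nM, which is a limit and not a number. Its steps from compound 1, compound 2 and compound 3 therefore cannot be read, and the series stays where it was: the limit of > 50000 nM in this assay, at which 4 of the 4 values shown sit.

The compounds shown leave open whether any change on the phenyl group alters the read-out, since none of them has a number of its own.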